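The compounds below may be only part of what the source reports. "The series", "measured", "known", "first", "only" and "open" are said of these compounds alone.

Measured in a physicochemical assay for acid dissociation:
- Compound 1 `CC#CCOc1noc2c1CNCC2`: 7.6
- Compound 2 `CCOc1noc2c1CN(C)CC2`: 6.6

Of these two numbers, the higher belongs to compound 1, at 7.6. The gap down to compound 2, at 6.6, lies beyond the usual scatter. These two compounds differ in more than one place, so their gap cannot be pinned on any single change.

Compound 3 `CCCOc1noc2c1CNCC2` has not yet been measured. Its structure departs from that of compound 1 in one place: ethyl in place of prop-1-yn-1-yl on a saturated chain carbon bound to an oxygen on an aromatic ring. Cut one bond further out, the same difference reads but-2-yn-1-yl to propyl.

Within the data shown here, no measured pair shows this change, so the expectation starts from compound 1 at 7.6, whose shared core stays untouched. The expected step, a number 0.20 log units higher from compound 1 to compound 3 (within the scatter), is small and upward, and not clearly beyond the scatter in this assay. Compound 3 is estimated at 7.8, with an expected range from 7.4 to 8.2.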

Compound 3, acid dissociation constant: 7.6
The estimate for compound 3 lay 0.20 log units above the measured number; low and high end bracket the measured number.
By their numbers in this assay, from the lowest: compound 2; then compounds 1 and 3 (each within the scatter of the next).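

Among these compounds, replacing the but-2-yn-1-yl chain with propyl is the first change in this set that can be read at a single place, and in this assay it gives no change at the digits printed from compound 1 to compound 3 (within the scatter). At this position, on a saturated chain carbon bound to an oxygen on an aromatic ring, the triple bond and one chain carbon can therefore go without a change in the read-out that stands out from the scatter, at least for this pair of chains. The compounds shown offer no measurement that could explain why the number stays in place, so the result records only what happened and not its cause.

Compound 2 still differs from compound 1 and from compound 3 in more than one place, so its number cannot yet be tied to any one of its structural differences. As far as these compounds go, it also stays open whether the same read-out would hold with a different group at this position, such as a chain ending in an amine or a carboxylic acid, or a longer chain such as hexyl.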